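Acetoxy added to the bicycle of compound 1

The compounds below may be only part of what the source reports. "The series", "measured", "known", "first", "only" and "open" are said of these compounds alone.

Compound 1 `CC(C)(C)c1cc(NC(=O)Nc2ccc(-c3cn4ccccc4n3)cc2)no1` is the reference of the set. In a functional assay on MV4-11 cells (Homo sapiens) for cytotoxicity, read by MTT assay, with a stated time of 72 h (on this read-out higher numbers stand for weaker inhibition and lower numbers for stronger inhibition), compound 1 gives 3.09 nM, the lowest of the three numbers measured. Compound 2 `CC(C)(C)c1cc(NC(=O)Nc2ccc(-c3cn4cccnc4n3)cc2)no1` gives 171 nM and compound 3 `CC(C)(C)c1cc(NC(=O)Nc2ccc(-c3nc4ccccc4s3)cc2)no1` gives 172 nM. Both differ from compound 1 only in the bicycle carried on the shared core, and both steps are large: a 55-fold higher number from compound 1 to compound 2 (1.74 log units; beyond the scatter) and a 56-fold higher number from compound 1 to compound 3 (1.75 log units; beyond the scatter). Between the two replacements the numbers are level, a 1.0-fold higher number from compound 2 to compound 3 (0.00 log units; within the scatter).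

Compound 4 `CC(=O)Oc1ccn2cc(-c3ccc(NC(=O)Nc4cc(C(C)(C)C)on4)cc3)nc2c1` keeps the bicycle of compound 1 intact and differs from it in a single substituent: acetoxy in place of hydrogen on an aromatic carbon. Going by the values given here, none of the measured steps bears on this change directly; each of them exchanges the whole bicycle for another, whereas here the bicycle of compound 1 stays and only a hydrogen on its six-membered ring is replaced. The measured steps say that this bicycle is worth keeping, and compound 4 keeps it. Among the compounds with values here, with no step of the same kind in the set, the expectation for compound 4 is a step of a 1.6-fold higher number from compound 1 to compound 4 (0.21 log units; within the scatter), with no direction preferred beyond the scatter. Compound 4 is estimated at 5 nM in this assay, within 1.5 nM to 30 nM.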

Compound 4, half-maximal inhibitory concentration: 29.4 nM
For compound 4 the middle estimate is 5.9-fold (0.77 log units) below the measured one; the measured number falls inside the stated range.
By their numbers in this assay, from the lowest: compound 1; then compound 4; then compounds 2 and 3 (each within the scatter of the next).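

In this assay, the aromatic carbon opposite the ring nitrogen, on the six-membered aromatic ring with 1 nitrogen, proves sensitive to substitution even with the bicycle left intact: acetoxy in place of hydrogen gives a 9.5-fold higher number from compound 1 to compound 4 (0.98 log units; beyond the scatter). This modest step is smaller than the large change seen on exchanging the whole bicycle, a 55-fold higher number from compound 1 to compound 2 (1.74 log units; beyond the scatter), and in the order of numbers compound 4 stands after compound 1 and before compounds 2 and 3, so the added acetoxy costs part of the advantage of compound 1 but not all of it. The data at hand offer no explanation for the size of this step.

Still open, going by these compounds, is whether the step belongs to acetoxy in particular or to any substituent on this carbon, a question that a hydroxy group, a methoxy group or a single fluorine at the same place would address. Equally open is whether acetoxy on another aromatic carbon of the same ring would give a step of similar size, since the compounds shown carry it at only one place.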